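Series notes: isopropyl oxadiazole in place of isopropyl thiazole

The source may hold more compounds than are shown below. What is called first, only, known or untested is meant among the compounds shown, and "the series" means these compounds.

Three compounds of the series carry numbers in an assay on isolated protein for inhibition of 2-Hydroxyacid oxidase 1 (Homo sapiens), with stated times of 30 min and 15 min; a higher number here means a weaker inhibitor, a lower number a stronger inhibitor. Compound 1 `CN(C)c1noc(-c2cccc(CN(C)c3ccc4[nH]nc(C(=O)O)c4c3)c2O)n1` gives 21 nM there, compound 2 `Cc1csc(-c2cccc(CNc3ccc4[nH]nc(C(=O)O)c4c3)c2O)n1` gives 23 nM, and compound 3 `CC(C)c1csc(-c2cccc(CNc3ccc4[nH]nc(C(=O)O)c4c3)c2O)n1` gives 65 nM. Compound 3 thus stands at the highest of the three numbers; the nearest is compound 2 and the furthest compound 1, both gaps beyond the scatter. Among the measured compounds shown here, the only single-place step recorded is a 2.8-fold higher number from compound 2 to compound 3 (0.45 log units; beyond the scatter), which concerns the substituent on the thiazole and not the ring itself.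

Compound 4 `CC(C)c1noc(-c2cccc(CNc3ccc4[nH]nc(C(=O)O)c4c3)c2O)n1` is next: 3-isopropyl-1,2,4-oxadiazol-5-yl in place of 4-isopropyl-1,3-thiazol-2-yl on an aromatic carbon. For the measured compounds named here, no measured step isolates this ring swap. Going by the values given here, compound 1 also carries a 1,2,4-oxadiazol-5-yl ring, but it differs from compound 3 in more than one place, so the two values show only that an oxadiazole-bearing member can sit at the lower end of the range seen so far. With the isopropyl kept, the expected step in this assay is a 1.4-fold lower number from compound 3 to compound 4 (0.16 log units; within the scatter), a small move toward lower numbers that may well stay within the scatter. For compound 4 the estimate in this assay is 45 nM, with a range from 18 nM to 120 nM.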

Compound 4, half-maximal inhibitory concentration in the 2-Hydroxyacid oxidase 1 assay: 47 nM
Compound 4: the middle estimate sits 1.0-fold (0.02 log units) below what was measured, within the range that was stated.
By their numbers in the 2-Hydroxyacid oxidase 1 assay, from the lowest: compounds 1 and 2 (each within the scatter of the next); then compounds 4 and 3 (each within the scatter of the next).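

In the 2-Hydroxyacid oxidase 1 assay, the ring swap on this aromatic carbon, ortho to a hydroxy group, gives a 1.4-fold lower number from compound 3 to compound 4 (0.14 log units; within the scatter), so with the isopropyl kept, the data separate the two rings by no more than the scatter. In the 2-Hydroxyacid oxidase 1 assay, the step from the methyl-bearing thiazole reads a 2.0-fold higher number from compound 2 to compound 4 (0.31 log units; beyond the scatter), a modest step that changes both the ring and its substituent and so cannot be assigned to either alone. The swap is not neutral in a physicochemical assay for solubility, measured as kinetic solubility, at pH 2 (a lower number here means a less soluble compound, a higher number a more soluble compound), where compound 3 gives 97000 nM and compound 4 gives 11000 nM, so compound 4 is the less soluble of the pair: the measured solubility of compound 3, 97000 nM, and of compound 4, 11000 nM, an 8.8-fold lower number (0.95 log units; beyond the scatter)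

Going by these compounds, a one-place comparison of a methyl with an isopropyl on the 1,2,4-oxadiazole ring remains open. Also open, on these data alone, is how a morpholine on that ring would fall in the 2-Hydroxyacid oxidase 1 assay and in the physicochemical assay.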